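The compounds below may be only part of what the source reports. "The series", "measured", "known", "first", "only" and "open" are said of these compounds alone.

Working notes on the anilide series in an ADME assay on microsomes from liver (Homo sapiens) for metabolic stability, with a stated time of 60 min; on this read-out lower numbers stand for a less stable compound and higher numbers for a more stable compound. Of the compounds shown here, three have numbers so far: compound 1 `Cc1ccc(NC(=O)CC(CCO)c2nnc(CCCC(C)C)n2C2CC2)c(C)c1`, compound 2 `Cc1ccc(NC(=O)C[C@H](CCC(=O)O)c2noc(-c3ccc(CC(C)C)cc3)c2C2CC2)c(Cl)c1` and compound 3 `Cc1ccc(NC(=O)C[C@H](CCC(=O)O)c2noc(-c3cc(CC(C)C)no3)c2C2CC2)c(Cl)c1`. In this assay compound 2 gives 80%, compound 3 gives 54% and compound 1 gives 21%. Compound 2 therefore stands highest of the three, with compound 3 nearest and compound 1 furthest; both gaps lie beyond the usual scatter.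

Compound 4 `Cc1ccc(NC(=O)C[C@H](CCC(=O)O)c2noc(-c3cc(CC(C)(C)C)on3)c2C2CC2)c(Cl)c1` has not yet been measured. Relative to compound 2 it carries 5-neopentyl-1,2-oxazol-3-yl in place of 4-isobutylphenyl on an aromatic carbon. Among the compounds with values here, the only measured step that bears on this exchange is the parallel swap of the same aryl group for an isoxazolyl group, which gave a number 26 percentage points lower from compound 2 to compound 3 (beyond the scatter). Because a number 26 percentage points lower from compound 2 to compound 3 (beyond the scatter) went downward by a modest but real margin, a downward step of comparable size is expected here as well; the neopentyl chain and the different ring attachment leave the direction uncertain, so the range is wide. Compound 4 is expected to give 55%, within 35% to 75%, corresponding to an estimated step of a number 25 percentage points lower from compound 2 to compound 4 (beyond the scatter).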

Compound 4, percent of the compound remaining: 84%
The estimate for compound 4 lay 29 percentage points below the measured number, and the stated range ends below it.
By their numbers in this assay, from the lowest: compound 1; then compound 3; then compounds 2 and 4 (each within the scatter of the next).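

In this assay, a 1,2-oxazole on this aromatic carbon need not lower the number relative to 4-isobutylphenyl: the exchange for 5-neopentyl-1,2-oxazol-3-yl gives a number 4 percentage points higher from compound 2 to compound 4 (within the scatter). The earlier fall with 3-isobutyl-1,2-oxazol-5-yl therefore does not extend to every 1,2-oxazole group at this place, and the exchange between the two such groups gives a number 30 percentage points higher from compound 3 to compound 4 (beyond the scatter). No supporting measurement accounts for this separation.

The two 1,2-oxazole groups differ in both ring attachment and side chain, so 5-isobutyl-1,2-oxazol-3-yl is the group that could show which of these carries the step. Also open, on these data alone, is whether a longer chain, such as 3,3-dimethylbutyl, on the same ring keeps the number of compound 4.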